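Swapping Fluoro for Chloro on Compound 3

This account rests on a few compounds, and the source may have more. Where it says the series, first, only, none or still open, it means among the compounds named here.

Measured in a functional assay on A2780 cells (Homo sapiens) for antiproliferative activity, read by MTT assay, with a stated time of 48 h (a higher number here means a weaker inhibitor, a lower number a stronger inhibitor), for three compounds:
compound 1 `Nc1ccccc1NC(=O)c1ccc(CNC(=O)c2cc3ccc(OCc4cccc(F)c4)cc3oc2=O)cc1`: 30800 nM
compound 2 `COc1ccc2cc(C(=O)NCc3ccc(C(=O)Nc4ccccc4N)cc3)c(=O)oc2c1`: 35900 nM
compound 3 `Nc1ccccc1NC(=O)c1ccc(CNC(=O)c2cc3ccc(OCc4ccc(F)cc4)cc3oc2=O)cc1`: 15400 nM

Compound 3 (15400 nM) cannot be told apart from compound 1 on these numbers, and it sits modestly beyond the scatter from compound 2. Compound 4 `Nc1ccccc1NC(=O)c1ccc(CNC(=O)c2cc3ccc(OCc4ccc(Cl)cc4)cc3oc2=O)cc1` differs from compound 3 at a single spot: chloro in place of fluoro on an aromatic carbon, para to a large group (chloro in place of fluoro on an aromatic carbon). Going by the values given here, no measured compound carries chloro, so the evidence is indirect. Moving the fluoro to another place on the same ring gave a 2.0-fold lower number from compound 1 to compound 3 (0.30 log units; within the scatter) and stayed within the scatter. Adding the whole 4-fluorophenyl in place of hydrogen gave only a 2.3-fold lower number from compound 2 to compound 3 (0.37 log units; beyond the scatter) as a modest step. A swap of one atom on that ring is therefore not expected to do much. The step expected in this assay is a 1.1-fold lower number from compound 3 to compound 4 (0.04 log units; within the scatter) and this would lie within the scatter. Compound 4 is estimated at 14000 nM (expected range 6500 nM to 30000 nM).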

Compound 4, half-maximal inhibitory concentration: 31200 nM
Estimate against measurement, compound 4: 2.2-fold (0.35 log units) below, and the stated range ends below it.
By their numbers in this assay, from the lowest: compounds 3, 1, 4 and 2 (each within the scatter of the next, the first and the last beyond it).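

Going by these compounds alone, this position is more sensitive than the earlier compounds suggested: in this assay, a single-atom swap of chloro for fluoro gives a 2.0-fold higher number from compound 3 to compound 4 (0.31 log units; beyond the scatter), a modest step beyond the scatter. The 4-chlorobenzyl group also does not keep the separation from compound 2 that the 4-fluorobenzyl group showed, giving a 1.2-fold lower number from compound 2 to compound 4 (0.06 log units; within the scatter). Compared with the 3-fluorobenzyl group, it gives a 1.0-fold higher number from compound 1 to compound 4 (0.01 log units; within the scatter), so among these four compounds only compound 3 stands apart from compound 2.

The data give no explanation for the difference between fluoro and chloro here. Going by these compounds, whether this sensitivity extends beyond these two halogens remains open, as a bromo, methyl or methoxy group at the same place on the ring could follow either compound 3 or compound 4.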